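The source may report more compounds than this note shows. Statements on the series, on what has been measured and on what is new or still open speak of the compounds shown alone.

Measured in a toxicity assay on HUVEC cells (Homo sapiens) for inhibition; a lower number here means a stronger inhibitor of growth, a higher number a weaker inhibitor of growth:
Compound 1 `Cc1nc(-c2ccccc2F)c(C(=O)N2CCN(c3cc(Cl)cc(Cl)c3)CC2)o1`: 0.177 ug/mL
Compound 2 `Cc1nc(-c2ccccc2)c(C(=O)N2CCN(c3cc(Cl)cc(Cl)c3)CC2)o1`: 0.191 ug/mL

Compound 2, at 0.191 ug/mL, stands within the scatter of compound 1, so the two cannot be told apart in this assay. Compound 3 `Cc1nc(-c2cccc(F)c2)c(C(=O)N2CCN(c3cc(Cl)cc(Cl)c3)CC2)o1` has not yet been measured. It differs from compound 2 by fluoro in place of hydrogen on an aromatic carbon, phenyl to 3-fluorophenyl.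

For the measured compounds named here, only one measured step bears on this change. It is a 1.1-fold higher number from compound 1 to compound 2 (0.03 log units; within the scatter), where the same two substituents are exchanged on the same ring, though not at the same carbon. Going by the values given here, that step lies within the scatter, but it is a single comparison, and no measurement yet shows what fluoro does at the new place. No shift beyond the scatter is therefore expected, and no direction can be favoured. The expected change is a 1.1-fold lower number from compound 2 to compound 3 (0.03 log units; within the scatter), which is no larger than the scatter. For compound 3 the estimated value is 0.18 ug/mL, with an expected range from 0.09 ug/mL to 0.36 ug/mL.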

Compound 3, concentration for 50% growth inhibition: 0.134 ug/mL
Compound 3: the middle estimate sits 1.3-fold (0.13 log units) above what was measured, within the range that was stated.
By their numbers in this assay, from the lowest: compounds 3, 1 and 2 (each within the scatter of the next).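

In this assay, for the compounds shown here, the first reading with fluoro at this carbon, meta to a large group, gives a 1.4-fold lower number from compound 2 to compound 3 (0.15 log units; within the scatter), so phenyl to 3-fluorophenyl does not shift the number beyond the scatter. Moving the fluorine, with 3-fluorophenyl in place of 2-fluorophenyl, gives a 1.3-fold lower number from compound 1 to compound 3 (0.12 log units; within the scatter), so the two fluoro placements cannot be told apart here, and neither can be told apart from the unsubstituted phenyl of compound 2. Among these three compounds, then, a single fluoro on this ring is tolerated at either carbon without a change that can be read, and no measurement offers any account of these numbers.

The compounds shown leave open whether a group other than fluoro on this ring, such as an amine, a carboxylic acid or a longer chain, would move the number beyond the scatter. They also leave open whether two fluoro groups together on the ring would behave as one does, since each compound here carries at most a single fluoro.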